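The source may hold more compounds than are shown below. What is called first, only, known or untested is meant among the compounds shown, and "the series" means these compounds.

Compound 1, `O=C1CC(c2ccc(F)cn2)CN1c1cnn2c1CN(C(=O)Nc1cc(F)c(F)c(F)c1)C(C1CC1)C2`, gives 38500 nM in a toxicity assay on HepG2 2.2.15 cells (Homo sapiens) for cytotoxicity, read by CellTiter-Glo; a higher number here means that more compound is tolerated, a lower number that less compound is tolerated.
Compound 2, `C[C@H]1Cn2ncc(N3CC(c4ccccc4)CC3=O)c2CN1S(=O)(=O)Nc1cc(F)c(F)c(F)c1`, gives > 2000 nM in this assay, a limit of the assay and not a number.
Compound 3, `C[C@H]1Cn2ncc(N3CC(c4ccccc4)CC3=O)c2CN1CC(=O)Nc1cc(F)c(F)c(F)c1`, gives > 2000 nM in this assay, again a limit and not a number.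

Within the data shown here, compound 1 thus holds the only measured number among the three; compounds 2 and 3 both sit at the limit of > 2000 nM in this assay, at which 2 of the 3 values shown sit. Among the measured compounds shown here, since each of those two values is a limit, no step between two measured compounds can be read from these data, and there is no measured step to scale what follows.

Compound 4, `O=C1CC(c2ncccn2)CN1c1cnn2c1CN(C(=O)Nc1cc(F)c(F)c(F)c1)C(C1CC1)C2`, is to be measured in this assay. It differs from compound 1 in one place: pyrimidin-2-yl in place of 5-fluoropyridin-2-yl on a saturated ring carbon. The rest of the shared core, including the urea bearing the trifluorophenyl group and the cyclopropyl group, is unchanged.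

With nothing to anchor a direction, the step is expected to be none beyond the scatter, so the estimate for the change from compound 1 to compound 4 is a 1.0-fold lower number from compound 1 to compound 4 (0.01 log units; within the scatter). Compound 4 is therefore expected to give about 38000 nM in this assay, within a range from 17000 nM to 85000 nM.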

Compound 4, half-maximal cytotoxic concentration: > 200000 nM
Compound 4 ended at the assay's limit; the forecaster's own chance of this, stated with the estimate: 30%; middle value at least 5.2-fold (0.72 log units) from the limit.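

Among these compounds, the exchange of 5-fluoropyridin-2-yl for pyrimidin-2-yl gives the first step that can be read in this assay: an at least 5.1-fold higher number from compound 1 to compound 4 (0.71 log units; beyond the scatter). This shows that the aromatic ring on this saturated ring carbon matters for how much compound is tolerated, even with the urea bearing the trifluorophenyl group and the cyclopropyl group unchanged. Compound 4 stands at a limit of the assay and not at a number: the limit of > 200000 nM in this assay, at which 1 of the 4 values shown sits.

The compounds shown leave open how pyridin-2-yl without the fluorine would stand at this ring carbon, and so whether the loss of the fluorine or the added ring nitrogen carries the step. They also leave open how a ring bearing an aminomethyl group or a carboxylic acid would fare at this position.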